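The compounds below may be only part of what the source reports. "The series", "measured", "known", "first", "only" and "open" are said of these compounds alone.

The shared core of the series appears in compound 1 `O=S(=O)(NC1CCN(S(=O)(=O)c2ccccc2)CC1)c1cc(S(=O)(=O)c2ccccc2)ccc1C(F)(F)F`, which in an assay on U2OS cells for inhibition of secreted frizzled-related protein 1 (Homo sapiens), read by a luciferase reporter, with a stated time of 18 h (a lower number here means that less compound is needed, a higher number that more compound is needed for the effect), gives 210 nM. Compound 2 `CC(C)(C)OC(=O)N1CCC[C@@H]1C(=O)N1CCC(NS(=O)(=O)c2cc(S(=O)(=O)c3ccccc3)ccc2C(F)(F)F)CC1` carries a 1-(tert-butoxycarbonyl)pyrrolidin-2-yl group on the carbonyl carbon, and in this assay compound 2 gives 210 nM. Compound 2 therefore stands level with compound 1 at the digits shown; the two values lie within the scatter of each other, and nothing further can be read from that pair.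

Compound 3 `O=C([C@@H]1CCNC1)N1CCC(NS(=O)(=O)c2cc(S(=O)(=O)c3ccccc3)ccc2C(F)(F)F)CC1` is the next compound awaiting measurement. It differs from compound 2 in a single place: pyrrolidin-3-yl in place of 1-(tert-butoxycarbonyl)pyrrolidin-2-yl on a carbonyl carbon. Among the measured compounds shown here, no measured pair in this set shows what such a change does, so there is no step on which to rest an expectation, and the only anchors are the values of compound 1 and compound 2. The account expects a small step in this assay toward more compound being needed, of a size that may still lie within the scatter, namely a 1.4-fold higher number from compound 2 to compound 3 (0.15 log units; within the scatter). Compound 3 is accordingly estimated at 300 nM, with a range from 100 nM to 900 nM.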

Compound 3, half-maximal effective concentration: 380 nM
Estimate against measurement, compound 3: 1.3-fold (0.10 log units) below, and the stated range covers the measured number.
By their numbers in this assay, from the lowest: compounds 1, 2 and 3 (each within the scatter of the next).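

In this assay, the move from 1-(tert-butoxycarbonyl)pyrrolidin-2-yl, with 12 heavy atoms, to pyrrolidin-3-yl, with 5, on a carbonyl carbon gives a 1.8-fold higher number from compound 2 to compound 3 (0.26 log units; within the scatter), so the first step read at this place stays within the scatter although the group entering is far smaller and carries a hydrogen-bond donor that the group leaving lacks. The comparison with the shared core of compound 1, where (pyrrolidin-3-yl)carbonyl stands in place of phenylsulfonyl on an amine nitrogen in a ring, gives a 1.8-fold higher number from compound 1 to compound 3 (0.26 log units; within the scatter), so phenylsulfonyl and (pyrrolidin-3-yl)carbonyl also cannot be told apart on this nitrogen. Nothing measured here offers an explanation for how small these steps are.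

The compounds shown leave open whether pyrrolidin-2-yl without its tert-butoxycarbonyl group, a piperidin-4-yl group or a carboxylic acid on this carbonyl carbon would stay within the scatter of these values, or whether any group here gives a step beyond it. The step to compound 3 also changes both the tert-butoxycarbonyl group and the point of attachment on the pyrrolidine at once, and the two changes remain unseparated.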